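The source may report more compounds than this note shows. Statements on the series, on what has been measured and on what is new or still open speak of the compounds shown alone.

Compound 1 `C[C@H]1[C@H](NCc2sccc2-c2ccccc2)C[C@H]2C[C@@H]1C2(C)C` carries a phenyl group on a five-membered sulfur-containing ring, linked through an amine to a bicyclic core. In an ADME assay on MDCK cells (Canis lupus familiaris) for cytotoxicity, read by microscopy, with a stated time of 48 h (a lower number here means that less compound is tolerated, a higher number that more compound is tolerated), compound 1 gives 12500 nM. Compound 2 `C[C@H]1[C@H](NCc2ccoc2)C[C@H]2C[C@@H]1C2(C)C` was tested in this assay and gives only a limit, > 100000 nM, not a number. Within the data shown here, compound 1 therefore stands as the only compound with a measured number in this assay, since the limit of > 100000 nM in this assay, at which 1 of the 2 values shown sits, applies to the other value. Compound 3 `C[C@H]1[C@H](NCc2sccc2C2CCCCC2)C[C@H]2C[C@@H]1C2(C)C` is the next compound to be examined; it differs from compound 1 in one place: cyclohexyl in place of phenyl on an aromatic carbon. Among the measured compounds shown here, no step between two measured compounds is available to guide the expectation, so the step from compound 1 to compound 3 is expected to stay within the usual scatter, no change at the digits printed from compound 1 to compound 3 (within the scatter). Compound 3 is expected to give 12500 nM in this assay, somewhere between 5000 nM and 40000 nM.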

Compound 3, minimum cytotoxic concentration: 1560 nM
Estimate against measurement, compound 3: 8.0-fold (0.90 log units) above; measured number below the stated range.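

In this assay, putting cyclohexyl in place of phenyl gives an 8.0-fold lower number from compound 1 to compound 3 (0.90 log units; beyond the scatter). This position, on an aromatic carbon two ring bonds from the ring sulfur, therefore responds to the kind of ring it carries, even though both groups have the same count of heavy atoms and neither has a hydrogen-bond donor or acceptor. No measurement shown explains why the non-aromatic ring is tolerated less well than the aromatic one.

Going by these compounds, it remains open whether a cyclopentyl group, or a phenyl ring carrying an amine or a methoxy group, would behave more like the phenyl of compound 1 or the cyclohexyl of compound 3. On these data alone, it is also open whether the same exchange would give a step of similar size on a different core.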